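Removing the para substituent from the aryl ring

A few compounds are considered here, and "the series" means these few. Any claim that something is new, unique, unknown or untested is made for them only; others in the source may bear on it.

For the measured compounds named here, compound 2 `Cc1ccc(-c2nc3sc(Cc4ccc(Cl)cc4)nn3c2SC#N)cc1` stands as the highest of the two numbers so far in a functional assay on HeLa cells (Homo sapiens) for cytotoxicity, with a stated time of 72 h (a higher number here means a weaker inhibitor, a lower number a stronger inhibitor), where compound 2 gives 22000 nM. Going by the values given here, its nearest neighbour is compound 1 `COc1ccc(-c2nc3sc(Cc4ccc(Cl)cc4)nn3c2SC#N)cc1`, which in this assay gives 9000 nM; the single measured step, a 2.4-fold higher number from compound 1 to compound 2 (0.39 log units; beyond the scatter), exchanges methoxy for methyl on an aromatic carbon. Compound 3 `N#CSc1c(-c2ccccc2)nc2sc(Cc3ccc(Cl)cc3)nn12` is not yet measured. It differs from compound 2 by hydrogen in place of methyl on an aromatic carbon, the same aromatic carbon that carries the methoxy in compound 1. Among the compounds with values here, only the step from compound 1 to compound 2 bears on this change, and it concerns a different exchange at that carbon; nothing measured shows what taking the methyl away does. That one step was modest, so a large move is not anticipated. The expected change in this assay is a 1.1-fold higher number from compound 2 to compound 3 (0.06 log units; within the scatter), with no confident direction and most likely within the scatter, the range kept wide for the unknown. Compound 3 is therefore estimated at 25000 nM, with a range from 9000 nM to 70000 nM.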

Compound 3, half-maximal inhibitory concentration: 12000 nM
Beside the measured number, compound 3's estimate is 2.1-fold (0.32 log units) above it, and the stated range covers the measured number.
By their numbers in this assay, from the lowest: compounds 1, 3 and 2 (each within the scatter of the next, the first and the last beyond it).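

Working notes on the carbon para to a large group: in this assay, replacing methyl with hydrogen gives a 1.8-fold lower number from compound 2 to compound 3 (0.26 log units; within the scatter), and replacing methoxy with hydrogen gives a 1.3-fold higher number from compound 1 to compound 3 (0.12 log units; within the scatter). Hydrogen therefore cannot be separated from either substituent at this position, although methoxy and methyl remain separated from each other by the one step beyond the scatter, so the three compounds do not divide into a substituted and an unsubstituted group. Nothing available explains these numbers or the gap between methoxy and methyl.

Still open, as far as these compounds go, is whether a group of another kind at this carbon, such as an amine, a hydroxyl, a carboxylic acid or a longer alkoxy chain, would stand beyond the scatter from hydrogen, which would show whether this position can shift the number appreciably in either direction. Also open, from the compounds shown here alone, is whether the exchanges among hydrogen, methyl and methoxy would read the same if the rest of the shared core, including the nitrile-bearing sulfur group, carried a different group.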